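The source may hold more compounds than are shown below. What is called first, only, known or untested is meant among the compounds shown, and "the series" means these compounds.

In a functional assay on HepG2 cells (Homo sapiens) for antiproliferative activity, read by MTT assay, with a stated time of 48 h (on this read-out lower numbers stand for an effect already at smaller amounts and higher numbers for an effect only at larger amounts of compound), compound 1 `CC1=NN(C(=O)c2ccc(F)cc2)C(c2ccccc2O)C1` gives 39200 nM and compound 3 `CC1=NN(S(=O)(=O)c2ccccc2C)C(c2cc(Br)ccc2O)C1` gives 39300 nM as measured numbers. Compound 2 `CC1=NN(S(=O)(=O)c2ccccc2)C(c2cc(Br)ccc2O)C1` shows > 60000 nM as a limit of the assay and not a number, so its true position is not known. Compound 4 `CC1=NN(S(=O)(=O)c2ccc([N+](=O)[O-])cc2)C(c2cc(Br)ccc2O)C1` differs from compound 2 by nitro in place of hydrogen on an aromatic carbon and so carries nitro in place of hydrogen on an aromatic carbon. Among the compounds with values here, the only measured step of this kind, an at least 1.5-fold lower number from compound 2 to compound 3 (0.18 log units; that floor lies within the scatter) with methyl entering, gives a floor within the scatter, so no step beyond the scatter is expected in this assay and any shift should be towards a slightly lower number. The expected step is an at least 1.3-fold lower number from compound 2 to compound 4 (0.12 log units; that floor lies within the scatter) and it rests on a limit. Compound 4 is estimated at 45000 nM with 18000 nM to 90000 nM as its expected range.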

Compound 4, half-maximal effective concentration: > 60000 nM
Compound 4 was reported as a limit; the forecaster's own chance of this, stated with the estimate: 40%; middle value at least 1.3-fold (0.12 log units) away from the limit.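

Compound 2 and compound 4 both stand at a limit and not at a number, so no step between them can be read: the limit of > 60000 nM in this assay, at which 2 of the 4 values shown sit.

As far as these compounds go, whether nitro in place of hydrogen on an aromatic carbon shifts the number in this assay at all, and by how much, stays open.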